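The compounds below may be only part of what the source reports. "The series", "measured", "known", "first", "only" and "open" are said of these compounds alone.

In a functional assay on aorta (strain Wistar) for inhibition, with Thoracic aorta (Rattus norvegicus) as the target (on this read-out lower numbers stand for stronger inhibition and higher numbers for weaker inhibition), compound 2, with the structure `CCn1cc(-c2cc(-c3cc4ccccc4o3)nc(OC)c2C#N)c2ccccc21`, gives 299000 nM. Compound 1, with the structure `CCOc1nc(-c2cc3ccccc3o2)cc(-c2cn(C)c3ccccc23)c1C#N`, gives in this assay 327000 nM. Of these two numbers, compound 2 has the lower one, yet the gap to compound 1 falls within the usual scatter of repeated measurements, so the two results cannot be told apart. Compound 3, with the structure `CCOc1nc(-c2cc3ccccc3o2)cc(-c2cn(CC)c3ccccc23)c1C#N`, has not yet been measured in this assay. It differs from compound 2 in one place: methyl in place of hydrogen on a saturated chain carbon bound to an oxygen on an aromatic ring. Compound 1 already carries the ethoxy group and gives a number that sits beside that of compound 2, so the change on this part of the shared core is expected to matter little. The step from compound 2 to compound 3 in this assay is estimated as a 1.0-fold higher number from compound 2 to compound 3 (0.00 log units; within the scatter), none beyond the scatter. Compound 3 is therefore expected to give about 300000 nM in this assay, within a range from 150000 nM to 650000 nM.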

Compound 3, half-maximal inhibitory concentration: 358000 nM
The estimate for compound 3 lay 1.2-fold (0.08 log units) below the measured number; measured number inside the range.
By their numbers in this assay, from the lowest: compounds 2, 1 and 3 (each within the scatter of the next).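

The change from methoxy to ethoxy can now be read directly: in this assay it amounts to a 1.2-fold higher number from compound 2 to compound 3 (0.08 log units; within the scatter) on an otherwise unchanged structure. A second place can also be read, since methyl in place of hydrogen on a saturated chain carbon bound to an aromatic nitrogen gives a 1.1-fold higher number from compound 1 to compound 3 (0.04 log units; within the scatter). At both places, then, this small addition leaves the result within the scatter, and no supporting measurement is available to explain this.

From the compounds shown here alone, whether a longer chain such as butyl, or an amine in place of the ethoxy group, would move the number beyond the scatter remains open. With all three results so close together, the compounds shown do not reveal which parts of the shared core matter for this read-out.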